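The source may report more compounds than this note shows. Statements on the series, on what has been measured and on what is new or still open speak of the compounds shown alone.

Measured compounds:
- compound 1, `CC(C)Sc1nnc(-c2c(CN3CCC(N4CCCC4)CC3)c3ccccc3n2C)n1-c1ccccc1`, in a physicochemical assay for lipophilicity (a lower number here means a more polar compound, a higher number a more lipophilic compound), gives 5.16
- compound 2, `CC(C)Sc1nnc(-c2c(CNc3cnccn3)c3ccccc3n2C)n1-c1ccccc1`, in this assay gives 4.22

Compound 2 stands lowest of the two numbers, with compound 1 being the nearest and higher value. Compound 3, `CC1CCN(Cc2c(-c3nnc(SC(C)C)n3-c3ccccc3)n(C)c3ccccc23)CC1`, has not yet been measured in this assay. The change from compound 2 to compound 3 is 4-methylpiperidin-1-yl in place of (pyrazin-2-yl)amino on a saturated chain carbon bound to an aromatic carbon. For the measured compounds named here, the only measured step that bears on this is a number 0.94 log units lower from compound 1 to compound 2 (beyond the scatter), which replaced a saturated ring amine with the same (pyrazin-2-yl)amino group at the same place. The change to compound 3 reverses that exchange, bringing back a saturated ring amine at that position, so a step upward of similar size is expected, a number 1.28 log units higher from compound 2 to compound 3 (beyond the scatter). Compound 3 is therefore expected to give about 5.5 in this assay, within a range from 4.9 to 6.1.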

Compound 3, partition coefficient: 5.96
Estimate against measurement, compound 3: 0.46 log units below; measured number inside the range.
By their numbers in this assay, from the lowest: compound 2; then compound 1; then compound 3.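

In this assay, the saturated chain carbon bound to an aromatic carbon now shows a wider span: 4-methylpiperidin-1-yl in place of (pyrazin-2-yl)amino gives a number 1.74 log units higher from compound 2 to compound 3 (beyond the scatter), a step graded large where the earlier exchange was modest. The saturated ring amine itself also matters, not only its presence, since methyl in place of pyrrolidin-1-yl on a saturated ring carbon gives a number 0.80 log units higher from compound 1 to compound 3 (beyond the scatter). Nothing available explains why the number moves in either step.

The compounds shown leave open where a plain piperidin-1-yl, with no group on its ring carbon, would fall relative to these two ring amines. Also open, as far as these compounds go, is how a hydroxyl or a carboxylic acid on that ring carbon, or an open-chain dimethylamino on the chain carbon, would compare.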